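Cytotoxicity notes: from compound 1 to compound 4

The source may report more compounds than this note shows. Statements on the series, on what has been measured and on what is new or still open speak of the compounds shown alone.

Measured so far in an ADME assay on Vero cells (Chlorocebus sabaeus) for cytotoxicity; a lower number here means that less compound is tolerated, a higher number that more compound is tolerated:
compound 1 `Nc1nc(-c2c(-c3ccc(F)cc3)nn3c(NC4CCCC4)cccc23)c[nH]1`: "not determined" (no result reported)
compound 2 `Fc1ccc(-c2nn3c(NC4CCCC4)cccc3c2-c2ccnc(NC3CCCC3)n2)cc1`: > 160000 nM
compound 3 `Fc1ccc(-c2nn3c(NC4CCCC4)cccc3c2-c2cc(NC3CCCC3)ncn2)cc1`: > 40000 nM

Compound 1 has no number in this assay. The two other values shown are limits of the assay, not numbers. Compound 2 sits at the limit of > 160000 nM in this assay, at which 1 of the 3 values shown sits. Compound 3 sits at the limit of > 40000 nM in this assay, at which 1 of the 3 values shown sits.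

Compound 4 `Fc1ccc(-c2nn3c(NC4CCCC4)cccc3c2-c2ccncc2)cc1` differs from compound 1 by pyridin-4-yl in place of 2-amino-1H-imidazol-4-yl on an aromatic carbon. Going by the values given here, no step between measured compounds exists in this assay, so the change from compound 1 to compound 4 is expected to give no shift beyond the scatter, with both measured compounds tolerated up to their limits. Compound 4 is estimated at 100000 nM, expected within 30000 nM to 300000 nM, and most likely reported only as a limit.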

Compound 4, half-maximal cytotoxic concentration: 20000 nM
Compound 4: the middle estimate sits 5.0-fold (0.70 log units) above what was measured; the measured number lies below the stated range.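

Going by these compounds alone, compound 1 has no number in this assay, so no step from compound 1 to compound 4 can be read. Left open is how pyridin-4-yl and 2-amino-1H-imidazol-4-yl compare on the shared core in this assay.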